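This account rests on a few compounds, and the source may have more. Where it says the series, first, only, none or still open, it means among the compounds named here.

Working notes on the series. Compound 1 `CCSc1nc2c(cc(-c3ccccc3)n2-c2ccccc2)c(=N)s1` is the parent with an unsubstituted phenyl on the shared core; in a functional assay on the whole organism for inhibition, with Rattus norvegicus as the target, read by ELISA, with stated times of 30 min and 6 h, at a dose of 30 mg/kg by the oral route (a lower number here means less inhibition, a higher number more inhibition at the dose given (going by the name of the read-out)), compound 1 gives 0%. Compound 2 `CCSc1nc2c(cc(-c3ccc(Cl)cc3)n2-c2ccccc2)c(=N)s1` carries chloro in place of hydrogen on an aromatic carbon, and in this assay compound 2 gives 1%. Compound 3 `CCSc1nc2c(cc(-c3ccc(C)cc3)n2-c2ccccc2)c(=N)s1` carries methyl in place of hydrogen on an aromatic carbon, and in this assay compound 3 gives 0%. Compound 3 therefore stands level with compound 1 at the digits shown, the two together the lowest of the three numbers, and its nearest and furthest neighbours are given by no change at the digits printed from compound 1 to compound 3 (within the scatter) and a number 1 percentage points lower from compound 2 to compound 3 (within the scatter), both within the scatter. In effect the numbers of all three measured compounds in this assay lie level with one another at this dose.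

Compound 4 `CCSc1nc2c(cc(-c3ccc(Br)cc3)n2-c2ccccc2)c(=N)s1` is the next step from compound 3: bromo in place of methyl on an aromatic carbon. Among the compounds with values here, the steps that bear on it are a number 1 percentage points higher from compound 1 to compound 2 (within the scatter), a halogen entering for hydrogen, and a number 1 percentage points lower from compound 2 to compound 3 (within the scatter), methyl replacing a halogen; neither moved the read-out beyond the scatter. Within the data shown here, no step on this aromatic carbon has shifted this assay, so no change beyond the scatter is expected for compound 4, and the step of a number 1 percentage points higher from compound 3 to compound 4 (within the scatter) is the estimate. Compound 4 is expected to give 1% in this assay, with a range of 0% to 8%.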

Compound 4, a percentage reported as inhibition, in the whole organism at one dose (the size of the read-out at that dose, not a potency): 1%
The estimate for compound 4 equals the measured number at the digits printed, within the range that was stated.
By their numbers in this assay, from the lowest: compounds 1, 3, 2 and 4 (each within the scatter of the next).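

Bromo is the third substituent on this aromatic carbon in this assay, and its steps read as follows: a number 1 percentage points higher from compound 1 to compound 4 (within the scatter), a number 1 percentage points higher from compound 3 to compound 4 (within the scatter) and no change at the digits printed from compound 2 to compound 4 (within the scatter). The 4-bromophenyl group of compound 4 therefore cannot be told apart from the unsubstituted phenyl of compound 1, the 4-methylphenyl group of compound 3 or the chloro-bearing phenyl of compound 2, so hydrogen, methyl, chloro and bromo at this place now all give numbers within the scatter of one another at this dose, with no exception among the four compounds. No measurement at hand offers an explanation for this flat picture.

On these data alone, what stays open is whether a group of a different kind at this place, such as an amine, a carboxylic acid or a longer chain, would give a number clear of the scatter. Also open is whether a change elsewhere on the shared core, for example on the other phenyl ring, would give inhibition that this aromatic carbon has so far not shown.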